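A few compounds are considered here, and "the series" means these few. Any claim that something is new, unique, unknown or untested is made for them only; others in the source may bear on it.

Of the compounds shown here, two carry the same core and have already been measured. Compound 1, `CCOC(=O)c1cccc(-c2ccc(O)cc2)c1`, bears an ethyl ester and a hydroxy group; in an assay on COS-7 cells for inhibition of patatin-like phospholipase domain-containing protein 2 (Mus musculus) (on this read-out higher numbers stand for weaker inhibition and lower numbers for stronger inhibition), compound 1 gives 100000 nM. Compound 2, `COC(=O)Nc1cccc(-c2ccc(N(C)C)cc2)c1`, instead bears a methyl carbamate and a dimethylamino group; in this assay compound 2 gives 5000 nM. Of the two numbers, compound 2 holds the lower one, and its distance to compound 1 lies beyond the scatter, so compound 2 is the stronger inhibitor of the pair.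

The next compound, compound 3, `CN(C)c1ccc(-c2cccc(NC(=O)N3CCOCC3)c2)cc1`, keeps the dimethylamino group and changes only the carbamate end: morpholin-4-yl in place of methoxy on a carbonyl carbon. The methoxycarbonyl thus becomes a (morpholin-4-yl)carbonyl, a urea in place of a carbamate. For the measured compounds named here, no measured pair shows this exact change, so the expectation rests on compound 2 alone. The value of compound 3 is expected to remain close to that of compound 2, perhaps slightly lower, an estimated step of a 2.0-fold lower number from compound 2 to compound 3 (0.30 log units; within the scatter). For compound 3 the estimate in this assay is 2500 nM, within a range from 500 nM to 12000 nM.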

Compound 3, half-maximal inhibitory concentration: > 200000 nM
Compound 3 was reported as a limit (the forecaster's own chance of this, stated with the estimate: 15%); middle value at least 80-fold (1.90 log units) away from the limit.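

At the carbonyl carbon, replacing methoxy with morpholin-4-yl gives an at least 40-fold higher number from compound 2 to compound 3 (1.60 log units; beyond the scatter) in this assay, so the inhibition seen with compound 2 is not kept after this single change. For the compounds shown here, this is the first comparison here between two compounds that differ in one place, and it shows that the group on this carbonyl carbon strongly affects the read-out, even with the dimethylamino group and the shared core unchanged; the two groups have the same counts of hydrogen-bond donors and acceptors and neither carries a net charge, so those counts do not separate them. For compound 3 the reported figure is a limit of the assay and not a number: the limit of > 200000 nM in this assay, at which 1 of the 3 values shown sits.

The compounds shown leave open whether the loss goes with the ring, with the larger number of heavy atoms, or with the switch from carbamate to urea. A methylamino group or a pyrrolidin-1-yl ring on the same carbonyl carbon would help to tell these possibilities apart.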